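Methoxy Additions on Two Aryl Cores in a Cytotoxicity Test

A few compounds are considered here, and "the series" means these few. Any claim that something is new, unique, unknown or untested is made for them only; others in the source may bear on it.

Compound 1 `COc1ccc(OC)c([C@H]2CC(C)(O)[C@@H]3CC[C@@H](C)C[C@H]3O2)c1` gives 512000 nM.
Compound 2 `COc1cc(OC)c([C@H]2CC(C)(O)[C@@H]3CC[C@@H](C)C[C@H]3O2)cc1OC` gives only a limit, > 857000 nM.
Compound 3 `C[C@@H]1CC[C@@H]2[C@@H](C1)O[C@@H](c1ccc(O)cc1)CC2(C)O` gives 127000 nM.

In an ADME assay on MDCK cells (Canis lupus familiaris) for cytotoxicity, read by MTT assay, with a stated time of 48 h (on this read-out higher numbers stand for lower toxicity in this test and lower numbers for higher toxicity in this test), compound 1 gives 512000 nM. For compound 2 the reading is a limit of the assay, > 857000 nM. Compound 3 gives 127000 nM, the lower of the two numbers. The difference between the cores of compound 1 and compound 3 is not broken down here. Compound 2 arises from compound 1 by methoxy in place of hydrogen on an aromatic carbon, and the step is an at least 1.6-fold higher number from compound 1 to compound 2 (0.22 log units; that floor lies within the scatter), its size a floor only because the limit of > 857000 nM in this assay, at which 1 of the 3 values shown sits, caps what could be read. Compound 4 `COc1cc([C@H]2CC(C)(O)[C@@H]3CC[C@@H](C)C[C@H]3O2)ccc1O` arises from compound 3 by methoxy in place of hydrogen on an aromatic carbon, the same kind of change, though here the entering group sits ortho to a hydroxy group and meta to a large group rather than ortho and meta to methoxy groups and para to a large group. For compound 4 a step of a 1.6-fold higher number from compound 3 to compound 4 (0.20 log units; within the scatter) is expected, resting on an at least 1.6-fold higher number from compound 1 to compound 2 (0.22 log units; that floor lies within the scatter). Compound 4 is therefore estimated at 200000 nM, likely between 90000 nM and 500000 nM.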

Compound 4, half-maximal cytotoxic concentration: 411000 nM
Beside the measured number, compound 4's estimate is 2.1-fold (0.31 log units) below it, and the stated range covers the measured number.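

In this assay methoxy in place of hydrogen on an aromatic carbon gives a 3.2-fold higher number from compound 3 to compound 4 (0.51 log units; beyond the scatter) on the core of compound 3, a step beyond the scatter. Set beside the same change on the core of compound 1, it reads: the same change on two cores in this assay, an at least 1.6-fold higher number (0.22 log units; that floor lies within the scatter) from compound 1 to compound 2 and a 3.2-fold higher number (0.51 log units; beyond the scatter) from compound 3 to compound 4; the limit leaves it open whether they differ. This shows a clear rise on one core only and does not show that the size of the step carries over, as the reading for compound 2 is a limit of the assay: the limit of > 857000 nM in this assay, at which 1 of the 4 values shown sits.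

The compounds shown leave open how an ethoxy group, a fluorine atom or an amine would act in place of methoxy. They also leave open whether the step holds with methoxy at other places on the aromatic ring.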